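A few compounds are considered here, and "the series" means these few. Any claim that something is new, unique, unknown or untested is made for them only; others in the source may bear on it.

In a functional assay on cells (Panel CNS (Carcinoma cell lines), Homo sapiens) for inhibition, read by sulforhodamine B assay, with a stated time of 48 h (on this read-out lower numbers stand for stronger inhibition of growth and higher numbers for weaker inhibition of growth), compound 1 `CN1CCN(CCCOc2cccc3nc(Nc4cccc(Cl)c4)ccc23)CC1` gives 1890 nM and compound 2 `CN1CCN(CCCOc2cccc3nc(Nc4cc(Cl)cc(Cl)c4)ccc23)CC1` gives 1720 nM. Compound 2 holds the lower of the two numbers, yet the step of a 1.1-fold lower number from compound 1 to compound 2 (0.04 log units; within the scatter) lies within the scatter, so the two compounds are not separated. Compound 3 `CN1CCN(CCCOc2cccc3nc(Nc4ccc(Cl)c(C(F)(F)F)c4)ccc23)CC1` differs from compound 2 by 4-chloro-3-(trifluoromethyl)phenyl in place of 3,5-dichlorophenyl on a nitrogen on an aromatic ring. Among the compounds with values here, only the step from compound 1 to compound 2 bears on this change, and it stayed within the scatter, so no step beyond the scatter is expected in this assay. Compound 3 is therefore expected to give about 1700 nM, between 700 nM and 4200 nM, a step of a 1.0-fold lower number from compound 2 to compound 3 (0.01 log units; within the scatter).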

Compound 3, concentration for 50% growth inhibition: 1650 nM
The estimate for compound 3 lay 1.0-fold (0.01 log units) above the measured number; low and high end bracket the measured number.
By their numbers in this assay, from the lowest: compounds 3, 2 and 1 (each within the scatter of the next).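

In this assay, the nitrogen on an aromatic ring now carries a group with a trifluoromethyl substituent, and 4-chloro-3-(trifluoromethyl)phenyl in place of 3,5-dichlorophenyl gives a 1.0-fold lower number from compound 2 to compound 3 (0.02 log units; within the scatter), while in place of 3-chlorophenyl it gives a 1.1-fold lower number from compound 1 to compound 3 (0.06 log units; within the scatter). All three aryl groups thus remain unseparated on this read-out, so the change from chloro alone to chloro plus trifluoromethyl has no resolved effect here. No supporting data bear on this result. Still open, on these data alone, is whether an unsubstituted phenyl, a cyclohexyl group or a phenyl bearing a carboxylic acid on this nitrogen would give a step beyond the scatter.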